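This account rests on a few compounds, and the source may have more. Where it says the series, first, only, none or still open, it means among the compounds named here.

Within the data shown here, in a physicochemical assay for solubility, read by HPLC, in phosphate buffer, with a stated time of 4 h, at pH 5.2 (on this read-out lower numbers stand for lower solubility and higher numbers for higher solubility), compound 2 `COc1ccc2c(c1)c(CC(=O)OCOC(=O)OC(C)C)c(C)n2C(=O)c1ccc(Cl)cc1` gives 0.119 ug/mL, the higher of the two numbers measured so far, though only by a margin within the scatter. Among the measured compounds shown here, compound 1 `COc1ccc2c(c1)c(CC(=O)OCOC(=O)C(C)(C)C)c(C)n2C(=O)c1ccc(Cl)cc1` gives 0.084 ug/mL, and the one measured step, a 1.4-fold higher number from compound 1 to compound 2 (0.15 log units; within the scatter), is within the scatter, so the two compounds cannot be placed in any order on this read-out. Compound 3 `COc1ccc2c(c1)c(CC(=O)OCCOC(C)=O)c(C)n2C(=O)c1ccc(Cl)cc1` is not yet measured. Its difference from compound 2 is acetoxymethyl in place of (isopropoxycarbonyl)oxy on a saturated chain carbon bound to an oxygen next to a carbonyl group. For the measured compounds named here, the only measured step bears on this change loosely: it too alters the group attached to the carbonyl carbon at the end of the ester chain, and it moved the number by no more than the scatter. The present change exchanges one group for another of the size counted above, at the same place in the chain, with no new ring and no change in charge. On the strength of that one step, compound 3 is expected to stay close to compound 2, with an expected step of a 1.3-fold higher number from compound 2 to compound 3 (0.10 log units; within the scatter). Compound 3 is therefore estimated at 0.15 ug/mL, within a range from 0.06 ug/mL to 0.4 ug/mL.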

Compound 3, solubility: 0.111 ug/mL
Beside the measured number, compound 3's estimate is 1.4-fold (0.13 log units) above it, and the stated range covers the measured number.
By their numbers in this assay, from the lowest: compounds 1, 3 and 2 (each within the scatter of the next).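

In this assay, among these compounds, the new step, a 1.1-fold lower number from compound 2 to compound 3 (0.03 log units; within the scatter), is within the scatter, and here the change reaches further than the one earlier step did. Cut one bond further out, it reads ((isopropoxycarbonyl)oxy)methyl to 2-acetoxyethyl, so the group on the saturated chain carbon bound to an oxygen next to a carbonyl group can be exchanged for acetoxymethyl without the number leaving the scatter. The other new step, a 1.3-fold higher number from compound 1 to compound 3 (0.12 log units; within the scatter), is also within the scatter, so compounds 1, 2 and 3 cannot be told apart on this read-out, and none of them goes against that picture; no separate measurement bears on why the three numbers lie so close together.

All the groups compared at this position are ester chains with no net charge, so the compounds shown leave open whether an amine, a carboxylic acid or a much longer alkyl chain in the same place would move the number in this assay beyond the scatter. They also leave open whether a change elsewhere on the shared core would do so.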